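A few compounds are considered here, and "the series" means these few. Any claim that something is new, unique, unknown or untested is made for them only; others in the source may bear on it.

Compound 1, whose structure is `COc1ccc(/C=C\c2cc(OC)c(OC)c(OC)c2)cc1OCc1ccc(CN2CC[C@H](C(=O)O)C2)cc1`, carries a 3-carboxypyrrolidin-1-yl group on a saturated chain carbon bound to an aromatic carbon. In a functional assay on HeLa cells (Homo sapiens) for antiproliferative activity, read by CCK-8 assay, with a stated time of 48 h (a higher number here means a weaker inhibitor, a lower number a stronger inhibitor), compound 1 gives only a limit of the assay, > 10000 nM. Compound 2, `COc1ccc(/C=C\c2cc(OC)c(OC)c(OC)c2)cc1OCc1ccc(CN2CC[C@@H](O)C2)cc1`, likewise gives only a limit in this assay, > 10000 nM. Compound 3, `COc1ccc(/C=C\c2cc(OC)c(OC)c(OC)c2)cc1OCc1ccc(CN2CCCCC2C(=O)NCCN)cc1`, gives 7300 nM in this assay. The measured steps show little: a step that the two limits leave unreadable from compound 1 to compound 2, and an at least 1.3-fold lower number from compound 1 to compound 3 (0.13 log units; that floor lies within the scatter), while an at least 1.3-fold lower number from compound 2 to compound 3 (0.13 log units; that floor lies within the scatter); the fact that two of the three values sit at the limit, (the limit of > 10000 nM in this assay, at which 2 of the 3 values shown sit), leaves the floor of these steps within the scatter. Compound 4, `COc1ccc(/C=C\c2cc(OC)c(OC)c(OC)c2)cc1OCc1ccc(CNC(C)(C)C(=O)O)cc1`, has not yet been measured. Relative to compound 1 the change is (1-carboxy-1-methylethyl)amino in place of 3-carboxypyrrolidin-1-yl on a saturated chain carbon bound to an aromatic carbon. As the acid group is kept and the shown steps read as no more than small, compound 4 is expected to remain weak, with a step that the limit leaves unreadable from compound 1 to compound 4 meaning no change beyond the scatter; its estimated value is 15000 nM, within 5000 nM to 50000 nM, most likely reported again as a limit.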

Compound 4, half-maximal inhibitory concentration: > 10000 nM
Compound 4: no number, only a limit; the forecaster's own chance of this, stated with the estimate: 70%; the middle value is on the limit's open side.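

Replacing 3-carboxypyrrolidin-1-yl with (1-carboxy-1-methylethyl)amino on a saturated chain carbon bound to an aromatic carbon leaves compound 4 at the limit of this assay, so a carboxy group without a ring now stands at that limit as well. The steps from compound 1 and from compound 2 to compound 4 cannot be read, and the only readable one is an at least 1.3-fold higher number from compound 3 to compound 4 (0.13 log units; that floor lies within the scatter). Only compound 3 gives a number, while the others stand at one limit: the limit of > 10000 nM in this assay, at which 3 of the 4 values shown sit.

From the compounds shown here alone, whether the ring itself matters stays open, since two limits give no size for this change. Going by these compounds, it also stays open whether a methyl ester in place of the carboxylic acid, or a dimethylamino group at this place, would give a number in this assay.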